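The source may report more compounds than this note shows. Statements on the series, on what has been measured and on what is new or still open speak of the compounds shown alone.

Going by the values given here, in a functional assay on HCT-116 cells (Homo sapiens) for cytotoxicity, read by crystal violet staining and colony formation, with a stated time of 7 days (a higher number here means a weaker inhibitor, a lower number a stronger inhibitor), compound 1 `C=CCOc1cc(O)c2c(c1)OC(c1ccc(O)cc1)CC2=O` gives 1910 nM, the lowest of the three numbers so far. Compound 2 `CCOC(=O)N/N=C1\CC(c2ccc(O)cc2)Oc2cc(O)cc(O)c21` gives 4350 nM, and compound 3 `Cc1ccccc1C(=O)Oc1cc(O)c2c(c1)OC(c1ccc(O)cc1)CC2=O` gives 6030 nM. Compound 4 `O=C(Oc1cc(O)c2c(c1)OC(c1ccc(O)cc1)CC2=O)c1cccs1`, not yet measured, changes one group of compound 1: (thiophen-2-yl)carbonyl in place of allyl on an oxygen on an aromatic ring. Among the compounds with values here, the one measured step of this kind puts (2-methylphenyl)carbonyl in place of that allyl, and it is modest: a 3.2-fold higher number from compound 1 to compound 3 (0.50 log units; beyond the scatter). Within the data shown here, with only this single step as a guide, a change of similar size in the same direction, towards a weaker inhibitor, is expected, estimated as a 2.6-fold higher number from compound 1 to compound 4 (0.42 log units; beyond the scatter). For compound 4 the estimated value is 5000 nM, with an expected range of 2300 nM to 11000 nM.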

Compound 4, half-maximal inhibitory concentration: 1200 nM
For compound 4 the middle estimate is 4.2-fold (0.62 log units) above the measured one; measured number below the stated range.
By their numbers in this assay, from the lowest: compounds 4 and 1 (each within the scatter of the next); then compounds 2 and 3 (each within the scatter of the next).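

In this assay, a carbonyl-linked aromatic ring on this oxygen need not weaken the compound: the replacement of allyl gives a 1.6-fold lower number from compound 1 to compound 4 (0.20 log units; within the scatter). The carbonyl link alone therefore does not account for the weaker number of compound 3, since thiophen-2-yl in place of 2-methylphenyl on the carbonyl carbon gives a 5.0-fold lower number from compound 3 to compound 4 (0.70 log units; beyond the scatter). No measurement shown here explains this difference between the two groups.

On these data alone, it remains open whether the methyl group or the phenyl ring of compound 3 matters more, as plain phenyl on the same carbonyl would help to show. As far as these compounds go, how furan-2-yl would behave there also remains unknown.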